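A Methyl Added to a Phenyl Ring on the Core

The source may report more compounds than this note shows. Statements on the series, on what has been measured and on what is new or still open speak of the compounds shown alone.

compound 1 `Cc1nnc(-c2nn(-c3ccccc3)c(-c3ccccc3)c2C#N)c2cn(-c3ccccc3)nc12`: 38400 nM
compound 2 `N#Cc1c(-c2nnc(-c3ccccc3)c3nn(-c4ccccc4)cc23)nn(-c2ccccc2)c1-c1ccccc1`: 31200 nM

In a functional assay on MDA-N cells (Homo sapiens) for inhibition, read by sulforhodamine B assay, with a stated time of 48 h (on this read-out higher numbers stand for weaker inhibition of growth and lower numbers for stronger inhibition of growth), compound 1 gives 38400 nM and compound 2 gives 31200 nM. Compound 2 stands at the lower of the two numbers. The gap is only a 1.2-fold lower number from compound 1 to compound 2 (0.09 log units; within the scatter), so the two are not told apart. Compound 3 `Cc1ccc(-n2cc3c(-c4nn(-c5ccccc5)c(-c5ccccc5)c4C#N)nnc(-c4ccccc4)c3n2)cc1` differs from compound 2 by methyl in place of hydrogen on an aromatic carbon. The one measured step concerns a different position and stayed within the scatter, so no shown step speaks directly to this change, and nothing points to a direction. Compound 3 is therefore expected to give about 31000 nM in this assay, with a range of 12000 nM to 80000 nM, an expected step of a 1.0-fold lower number from compound 2 to compound 3 (0.00 log units; within the scatter).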

Compound 3, concentration for 50% growth inhibition: > 100000 nM
Compound 3 was reported as a limit (the forecaster's own chance of this, stated with the estimate: 10%); at least 3.2-fold (0.50 log units) between middle value and limit.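

Compound 3 is reported only as a limit in this assay, > 100000 nM. This shows that the phenyl ring is not indifferent to change at the place para to a large group: methyl in place of hydrogen gives an at least 3.2-fold higher number from compound 2 to compound 3 (0.50 log units; beyond the scatter), meaning weaker inhibition of growth, unlike the earlier step at a different position, which stayed within the scatter. The true size of this step remains unknown, as the reading stops at: the limit of > 100000 nM in this assay, at which 1 of the 3 values shown sits.

The compounds shown leave open whether a fluorine atom, a methoxy group or an amine at this same place would also weaken inhibition of growth.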